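The source may report more compounds than this note shows. Statements on the series, on what has been measured and on what is new or still open speak of the compounds shown alone.

Measured compounds in a toxicity assay on THP-1 cells (Homo sapiens) for inhibition; on this read-out higher numbers stand for lower toxicity in this test and lower numbers for higher toxicity in this test:

compound 1 `COc1ccc(-c2cnc(NC(=O)c3ccccc3C)n2C)cc1`: compound 1 gives > 100000 nM, which is a limit of the assay and not a number.
compound 2 `Cn1c(-c2ccccc2)cnc1NC(=O)c1ccccc1Cl`: compound 2 gives > 50000 nM, likewise a limit.
compound 3 `Cn1c(-c2ccccc2Br)cnc1NC(=O)c1ccc(F)cc1`: compound 3 gives > 100000 nM, again a limit.

Compound 2 stands only at a limit in this assay; the two further values shown are limits as well, two of the three sitting at the limit of > 100000 nM in this assay, at which 2 of the 3 values shown sit, and one at the limit of > 50000 nM in this assay, at which 1 of the 3 values shown sits. For the measured compounds named here, no pair of measured compounds differs in one place, so no measured step size is available.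

Compound 4 `Cn1c(-c2ccccc2)cnc1NC(=O)c1ncc[nH]1` is not yet measured in this assay. It differs from compound 2 by 1H-imidazol-2-yl in place of 2-chlorophenyl on a carbonyl carbon.

With all three measured values at a limit, the step that the limit leaves unreadable from compound 2 to compound 4 is expected to be none beyond the scatter, most probably with the result again reported as a limit. Compound 4 is estimated at 80000 nM in this assay, with a range from 25000 nM to 200000 nM.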

Compound 4, half-maximal cytotoxic concentration: > 100000 nM
Compound 4 ended at the assay's limit; the forecaster's own chance of this, stated with the estimate: 85%; middle value at least 1.2-fold (0.09 log units) from the limit.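

In this assay compound 4 gives > 100000 nM, a limit. For the compounds shown here, compound 2 gives > 50000 nM, also a limit, so no step from compound 2 to compound 4 can be read. The compounds shown leave open whether any change to the shared core gives a measurable value in this assay.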